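The source may report more compounds than this note shows. Statements on the series, on what has been measured and on what is new or still open speak of the compounds shown alone.

Among the measured compounds shown here, compound 1 `Cc1ccc(-c2nc(N)c3cc(Cc4ccccc4)sc3n2)o1` is one of two compounds measured in a functional assay on CHO-K1 cells for antagonist activity at adenosine receptor A1 (Homo sapiens), read by a beta-galactosidase reporter and cAMP accumulation, with stated times of 15 min and 6 h; a higher number here means a weaker inhibitor, a lower number a stronger inhibitor. In that test compound 1 gives 298 nM, the higher of the two numbers, so it is the weaker of the pair. The other measured compound, compound 2 `Cc1ccc(-c2nc(N)c3cc(Cc4ccccc4Cl)sc3n2)o1`, gives 26.1 nM in this assay. For the measured compounds named here, the only change recorded between them is an 11-fold lower number from compound 1 to compound 2 (1.06 log units; beyond the scatter), and that change sits on the benzyl ring, far from the furan.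

Compound 3 `Nc1nc(-c2ccc(C3CC3)o2)nc2sc(Cc3ccccc3)cc12` is not yet measured. It differs from compound 1 by cyclopropyl in place of methyl on an aromatic carbon. Going by the values given here, no measured step touches the furan, so the one step that exists, from compound 1 to compound 2, does not bear on this change and gives no direction for it. With nothing to go on beyond the shared core, the expectation is a step that stays within the usual scatter, in either direction.

The expected step from compound 1 to compound 3 is therefore a 1.5-fold lower number from compound 1 to compound 3 (0.17 log units; within the scatter), and compound 3 is estimated at 200 nM in this assay, with a range from 60 nM to 700 nM.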

Compound 3, inhibition constant: 861 nM
Compound 3: the middle estimate sits 4.3-fold (0.63 log units) below what was measured; the whole stated range lies below it.
By their numbers in this assay, from the lowest: compound 2; then compound 1; then compound 3.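

The carbon next to the ring oxygen of the furan turns out not to be a neutral spot: in this assay, replacing 5-methylfuran-2-yl with 5-cyclopropylfuran-2-yl gives a 2.9-fold higher number from compound 1 to compound 3 (0.46 log units; beyond the scatter) and so a weaker inhibitor. Among the compounds shown here, the step is modest, but it is the first measured sign that the group at this carbon matters, which the earlier pair could not show, as its one change lay on the benzyl ring. No measurement here accounts for the loss, so it stands as an observation without an explanation.

A single step cannot show whether the number keeps rising as the group at this carbon grows, or whether cyclopropyl is a special case; an ethyl or isopropyl group, or a plain hydrogen, would help to separate those readings. On these data alone, it also remains open whether the gain from the chloro group on the benzyl ring, seen as an 11-fold lower number from compound 1 to compound 2 (1.06 log units; beyond the scatter), would carry over to the cyclopropyl series, and how an amine at the furan carbon would behave.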